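Cyclopropyl to propyl on the amino nitrogen: working notes

The source may report more compounds than this note shows. Statements on the series, on what has been measured and on what is new or still open speak of the compounds shown alone.

Measured in an ADME assay on Akata cells (Homo sapiens) for cytotoxicity, with a stated time of 7 days; a higher number here means that more compound is tolerated, a lower number that less compound is tolerated:
- Compound 1 `Nc1nc(NCc2ccccc2)c2ncn(/C=C3/CC3(CO)CO)c2n1`: > 24000 nM (a limit)
- Compound 2 `Nc1nc(NC2CC2)c2ncn(/C=C3/CC3(CO)CO)c2n1`: > 20000 nM (a limit)

Compound 2 stands at > 20000 nM, which is a limit and not a number. Compound 1 likewise gives only a limit, > 24000 nM. Compound 3 `CCCNc1nc(N)nc2c1ncn2/C=C1/CC1(CO)CO` has propyl in place of cyclopropyl on a nitrogen on an aromatic ring. Among the measured compounds shown here, the only measured step that bears on this change is a step that the two limits leave unreadable from compound 1 to compound 2, so it sets no size to carry over. No step beyond the scatter is therefore expected in this assay, in either direction, and a further limit is the likeliest report for compound 3. The expected step, a number no higher from compound 2 to compound 3 (the limit leaves the size open), is an estimate resting on compound 2 at > 20000 nM. Compound 3 is estimated at 20000 nM, with an expected range of 8000 nM to 30000 nM.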

Compound 3, half-maximal cytotoxic concentration: > 24000 nM
Compound 3: a limit, no number; the forecaster's own chance of this, stated with the estimate: 75%; middle value at least 1.2-fold (0.07 log units) away from the limit.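

In this assay compound 3 gives > 24000 nM, a limit and not a number. Compound 1, compound 2 and compound 3 all stand at limits, and no step can be read among them. The compounds shown leave open where each half-maximal cytotoxic concentration lies, and whether these changes shift it at all.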